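This account rests on a few compounds, and the source may have more. Where it says the series, first, only, none or still open, it means among the compounds named here.

Compound 1 `C/C(=N\OCc1ccncc1)c1ccc(Sc2cc(F)cc(C3CCOCC3)c2)cc1` gives 300 nM in a functional assay (blood) for inhibition, with Homo sapiens as the target; on this read-out lower numbers stand for stronger inhibition and higher numbers for weaker inhibition.
Compound 2 `COC1(c2cc(F)cc(Sc3ccc4c(c3)CC/C4=N\O)c2)CCOCC1` gives 290 nM in this assay.
Compound 3 `CO[C@]1(c2cnc(S(=O)(=O)c3ccc(/C(C)=N/O)cc3)s2)CCO[C@@H](C)C1` gives 320 nM in this assay.

These three numbers lie so close together that none can be told apart from the others: compound 1 sits within the usual scatter of both compound 2 and compound 3, so the three compounds look alike on this read-out. Compound 4 `CC(=O)O/N=C(\C)c1ccc(Sc2cc(F)cc(C3CCOCC3)c2)cc1` has not yet been measured. It differs from compound 1 in one place only: acetyl in place of (pyridin-4-yl)methyl on an oxygen. Among the measured compounds shown here, no pair of measured compounds shares this change, so there is nothing to calibrate its effect against, and the direction of any step in this assay remains open. A swap of this size, exchanging a ring-bearing group for a short one on the same oxygen, is expected to move the number by at most a modest amount, possibly no further than the scatter itself. The step from compound 1 to compound 4 is therefore expected to be a 1.7-fold higher number from compound 1 to compound 4 (0.22 log units; within the scatter), a small shift with a wide uncertainty. Compound 4 is estimated at 500 nM, with a likely range from 150 nM to 1800 nM.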

Compound 4, half-maximal inhibitory concentration: 50 nM
Compound 4: middle estimate off by 10-fold (1.00 log units), on the high side; the whole stated range lies above it.
By their numbers in this assay, from the lowest: compound 4; then compounds 2, 1 and 3 (each within the scatter of the next).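

In this assay, this oxygen proves to be a place where a single change moves the number: acetyl in place of (pyridin-4-yl)methyl gives a 6.0-fold lower number from compound 1 to compound 4 (0.78 log units; beyond the scatter), a step beyond the scatter. The earlier compounds shown here could not show this, as they sat within the scatter of one another and no two of them differed in only one place. Nothing measured here accounts for the step.

This one step swaps a group holding a ring for a smaller one with a double bond and no ring, so it cannot show which of these differences matters. Also open, going by these compounds, is whether a plain methyl or a longer acyl chain such as butanoyl on the same oxygen would give a number nearer to that of compound 4 or compound 1.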